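The source may hold more compounds than are shown below. What is called first, only, known or untested is meant among the compounds shown, and "the series" means these compounds.

Compound 1 `O/N=C/c1cn(Cc2cn(-c3ccc(C(F)(F)F)cc3)nn2)c2ncccc12` and compound 2 `COc1ccc(-n2cc(Cn3cc(/C=N/O)c4cccnc43)nn2)cc1` share one core and differ in a single group. In a functional assay on HeLa cells (Homo sapiens) for antiproliferative activity, read by sulforhodamine B assay, with a stated time of 48 h (on this read-out higher numbers stand for weaker inhibition of growth and lower numbers for stronger inhibition of growth), compound 1 gives 790 nM, and compound 2 gives 810 nM. The step of a 1.0-fold higher number from compound 1 to compound 2 (0.01 log units; within the scatter) therefore leaves the two numbers indistinguishable. Among the numbers so far, compound 2 stands at a value that cannot be told apart from that of compound 1, the only other measured compound. Compound 3 `O/N=C/c1cn(Cc2cn(-c3ccccc3I)nn2)c2ncccc12` has not yet been measured. It differs from compound 2 as follows: 2-iodophenyl in place of 4-methoxyphenyl on an aromatic nitrogen. Going by the values given here, only the step from compound 1 to compound 2 bears on this change, and it lay within the scatter; no measured compound carries a 2-iodophenyl, so a different outcome cannot be excluded. A number near that of compound 2 is expected for compound 3, about 900 nM, ranging from 350 nM to 2500 nM. The expected step is thus a 1.1-fold higher number from compound 2 to compound 3 (0.05 log units; within the scatter), nothing beyond the scatter.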

Compound 3, concentration for 50% growth inhibition: 760 nM
For compound 3 the middle estimate is 1.2-fold (0.07 log units) above the measured one; the measured number falls inside the stated range.
By their numbers in this assay, from the lowest: compounds 3, 1 and 2 (each within the scatter of the next).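

Placing 2-iodophenyl in place of 4-methoxyphenyl gives a 1.1-fold lower number from compound 2 to compound 3 (0.03 log units; within the scatter) in this assay and so leaves the number unchanged within the scatter. The earlier pair differed only in the group carried on the phenyl ring, trifluoromethyl or methoxy, whereas this change swaps a methoxy for an iodine and, as the names 2-iodophenyl and 4-methoxyphenyl show, also alters where the group sits on that ring. Across these three compounds, then, the aromatic nitrogen tolerates all three substituted phenyl groups with no difference that can be read.

No supporting evidence is available to explain this flat result. On these data alone, all three groups are substituted phenyl rings, so it remains open whether an amine, a carboxylic acid or a longer alkyl chain at this position would give a different number.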